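The source may hold more compounds than are shown below. What is called first, only, known or untested is meant among the compounds shown, and "the series" means these compounds.

Of the compounds shown here, three sharing one core have been measured in a functional assay on NIH3T3 cells for agonist activity at Urotensin-2 receptor (Homo sapiens), with a stated time of 5 days; on this read-out higher numbers stand for an effect only at larger amounts of compound and lower numbers for an effect already at smaller amounts. Compound 1 `Cc1ccc(C(CCN(C)C)NC(=O)C#Cc2ccccc2)cc1` gives 3090 nM, the highest number of the three. Compound 2 `CN(C)CCC(NC(=O)C#Cc1ccccc1)c1ccc(Cl)cc1` gives 398 nM, and compound 3 `CN(C)CCC(NC(=O)CCc1ccccc1)c1ccc(Cl)cc1` gives 1660 nM. The step of a 7.8-fold lower number from compound 1 to compound 2 (0.89 log units; beyond the scatter) is beyond the scatter, whereas compound 1 and compound 3 lie within the scatter of each other.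

Compound 4 `Cc1ccc(C(CCN(C)C)NC(=O)/C=C/c2ccccc2)cc1` differs from compound 1 in one place: 2-phenylethenyl in place of 2-phenylethynyl on a carbonyl carbon. For the measured compounds named here, only one measured step speaks to this kind of change, a 4.2-fold higher number from compound 2 to compound 3 (0.62 log units; beyond the scatter), where the triple bond outside the aromatic ring is lost and a fully single-bonded chain enters. In compound 4 the chain keeps one double bond, so the change lies part way toward that of compound 3, and a smaller rise in number than the step from compound 2 to compound 3 is expected, in the same direction. For compound 4 the expected step is a 1.8-fold higher number from compound 1 to compound 4 (0.25 log units; within the scatter). Compound 4 is therefore estimated at 5500 nM, with a range from 2500 nM to 12000 nM.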

Compound 4, half-maximal effective concentration: 1550 nM
Beside the measured number, compound 4's estimate is 3.5-fold (0.55 log units) above it; measured number below the stated range.
By their numbers in this assay, from the lowest: compound 2; then compounds 4, 3 and 1 (each within the scatter of the next).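

On the core of compound 1, 2-phenylethenyl in place of 2-phenylethynyl on a carbonyl carbon gives a 2.0-fold lower number from compound 1 to compound 4 (0.30 log units; within the scatter), so here a double bond in place of the triple bond produces no readable change. For the compounds shown here, the only earlier change at this position, a 4.2-fold higher number from compound 2 to compound 3 (0.62 log units; beyond the scatter), lies beyond the scatter, but it brought in phenethyl and sits on the chloro compounds, so the two steps cannot be set directly against each other. Nothing measured here explains why the new step stays within the scatter.

Still open, on these data alone, is how 2-phenylethenyl would read on the core of compound 2, and how phenethyl would read on the core of compound 1. Also open, as far as these compounds go, is whether a longer chain between the carbonyl carbon and the phenyl ring would still give a response in this assay.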